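This account rests on a few compounds, and the source may have more. Where it says the series, first, only, none or still open, it means among the compounds named here.

Measured so far:
compound 1 `COc1ccc(N(C)c2nc(C)nc3ccccc23)cc1OCCC[Se]C#N`: 1040 nM
compound 2 `Cc1nc(N(C)c2ccc([Se]C#N)c(C)c2)c2ccccc2n1`: 9 nM

In a functional assay on HepG2 cells (Homo sapiens) for inhibition, read by MTT assay, with a stated time of 48 h (a higher number here means a weaker inhibitor, a lower number a stronger inhibitor), compound 1 stands at the highest of the two numbers, 1040 nM; compound 2 sits far lower, at 9 nM, and that gap is beyond the scatter. Compound 3 `COc1ccc(N(C)c2nc(C)nc3ccccc23)cc1OCCCCC[Se]C#N` differs from compound 1 by a group of 5 heavy atoms (3 carbon, 1 nitrogen, 1 selenium; no ring) in place of a group of 3 heavy atoms (1 carbon, 1 nitrogen, 1 selenium; no ring), on a saturated chain carbon, three bonds along the chain from an oxygen on an aromatic ring. Within the data shown here, no measured pair tests such a change, so nothing here sets a direction; in this assay a step of no more than the scatter is expected, either way. Compound 3 is therefore estimated at 850 nM (range 300 nM to 2500 nM), an expected step of a 1.2-fold lower number from compound 1 to compound 3 (0.09 log units; within the scatter), within the scatter.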

Compound 3, half-maximal inhibitory concentration: 5210 nM
Beside the measured number, compound 3's estimate is 6.1-fold (0.79 log units) below it; measured number outside the range, above it.
By their numbers in this assay, from the lowest: compound 2; then compound 1; then compound 3.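

This position responds to the size of the group: in this assay, a group of 5 heavy atoms (3 carbon, 1 nitrogen, 1 selenium; no ring) in place of a group of 3 heavy atoms (1 carbon, 1 nitrogen, 1 selenium; no ring) gives a 5.0-fold higher number from compound 1 to compound 3 (0.70 log units; beyond the scatter), so the longer group weakens inhibition here. No available data explain this step. A single step sets no trend with length. A group with one further carbon, a still longer chain, or an amine or carboxylic acid at this place remains an open test.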